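A few compounds are considered here, and "the series" means these few. Any claim that something is new, unique, unknown or untested is made for them only; others in the source may bear on it.

Three sulfonamides built on one shared core have been tested in a functional assay on M21 cells (Homo sapiens) for antiproliferative activity, read by sulforhodamine B assay, with a stated time of 48 h; a higher number here means a weaker inhibitor, a lower number a stronger inhibitor. Compound 2 `O=C1NCCN1c1ccc(S(=O)(=O)Nc2ccccc2)cc1` gives 200 nM in this assay. Compound 3 `CCCCCc1ccc(NS(=O)(=O)c2ccc(N3CCNC3=O)cc2)cc1` gives 870 nM. Compound 1 `O=C1NCCN1c1ccc(S(=O)(=O)Nc2ccc(C3CCCCC3)cc2)cc1` gives > 1000 nM, which is a limit of the assay rather than a number. Among the numbers shown, compound 2 stands lowest, and compound 3 is its nearest neighbour with a 4.4-fold higher number from compound 2 to compound 3 (0.64 log units; beyond the scatter) for pentyl in place of hydrogen on an aromatic carbon. The other measured step, hydrogen in place of cyclohexyl on an aromatic carbon, reads an at least 5.0-fold lower number from compound 1 to compound 2 (0.69 log units; beyond the scatter); it rests on (the limit of > 1000 nM in this assay, at which 1 of the 3 values shown sits), so only its floor is known.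

Compound 4 `Cc1ccccc1NS(=O)(=O)c1ccc(N2CCNC2=O)cc1` is the next step from compound 2: methyl in place of hydrogen on an aromatic carbon. Methyl is a much smaller addition than pentyl or cyclohexyl, and both of those larger groups pushed the number up or onto a limit. A small rise in this assay, possibly none beyond the scatter, is therefore expected for compound 4. The step of a 1.6-fold higher number from compound 2 to compound 4 (0.20 log units; within the scatter) is the estimated outcome. Compound 4 is expected to give about 320 nM, within a range from 130 nM to 800 nM.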

Compound 4, half-maximal inhibitory concentration: 150 nM
Compound 4: the middle estimate sits 2.1-fold (0.33 log units) above what was measured, and the stated range covers the measured number.
By their numbers in this assay, from the lowest: compounds 4 and 2 (each within the scatter of the next); then compound 3. At a limit, above all of these: compound 1.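

Compound 4 is the first compound shown with a group added to the phenyl ring of compound 2 that does not separate from it in this assay: a 1.3-fold lower number from compound 2 to compound 4 (0.12 log units; within the scatter). The ring therefore accepts a methyl, ortho to a large group, with no loss that can be read from these numbers, whereas the step to the pentyl compound, a 4.4-fold higher number from compound 2 to compound 3 (0.64 log units; beyond the scatter), lies beyond the scatter. Nothing measured here gives a reason why one added group stays within the scatter and the other does not.

On these data alone, what stays open is how much can be placed at this same spot before the number moves, since an ethyl, a longer chain, an amine or a carboxylic acid there would each test this further. A methyl on the other carbons of the ring is open as well, and until such a compound stands beside compound 4, the effect of the size of a group cannot be told apart from the effect of where it sits.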